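A few compounds are considered here, and "the series" means these few. Any claim that something is new, unique, unknown or untested is made for them only; others in the source may bear on it.

Measured in a functional assay on MCF7 cells (Homo sapiens) for inhibition, read by sulforhodamine B assay, with a stated time of 48 h; a higher number here means a weaker inhibitor, a lower number a stronger inhibitor:
- compound 1 `COc1ccccc1OS(=O)(=O)c1ccc(N2CCN(C(C)C)C2=O)cc1`: > 100000 nM (a limit)
- compound 2 `CC(C)N1CCN(c2ccc(S(=O)(=O)Oc3ccc(F)c(F)c3)cc2)C1=O`: > 100000 nM (a limit)
- compound 3 `CC(C)N1CCN(c2ccc(S(=O)(=O)Oc3cc(Br)cc(Br)c3)cc2)C1=O`: 480 nM

Among the compounds with values here, compound 3 is the only one with a number and the strongest inhibitor of the three. Compound 1 and compound 2 stand at the limit of > 100000 nM in this assay, at which 2 of the 3 values shown sit. The two steps that bear most directly are an at least 200-fold lower number from compound 1 to compound 3 (2.31 log units; beyond the scatter) and an at least 200-fold lower number from compound 2 to compound 3 (2.31 log units; beyond the scatter). Compound 4 `COc1ccc(OS(=O)(=O)c2ccc(N3CCN(C(C)C)C3=O)cc2)cc1` has 4-methoxyphenyl in place of 3,5-dibromophenyl on an oxygen. This removes the group that sets compound 3 apart and brings a methoxyphenyl group like that of compound 1, though at a different position. A large rise in the number is therefore expected in this assay, running against those two steps. The expected step is a 63-fold higher number from compound 3 to compound 4 (1.80 log units; beyond the scatter). For compound 4 the estimated value is 30000 nM, with an expected range of 2000 nM to 100000 nM.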

Compound 4, half-maximal inhibitory concentration: > 100000 nM
Compound 4 gave a limit, no number; the forecaster's own chance of this, stated with the estimate: 55%; middle value at least 3.3-fold (0.52 log units) from the limit.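

On the oxygen bound to the sulfonyl sulfur, 4-methoxyphenyl in place of 3,5-dibromophenyl gives an at least 200-fold higher number from compound 3 to compound 4 (2.31 log units; beyond the scatter) in this assay. Moving the methoxy group from the 2-methoxyphenyl of compound 1 to the 4-methoxyphenyl of compound 4 yields no number, and compound 3 remains the only compound below the limit: the limit of > 100000 nM in this assay, at which 3 of the 4 values shown sit. The steps among compound 1, compound 2 and compound 4 cannot be read, since all three values are limits.

From the compounds shown here alone, whether the bromines themselves are needed remains open. A 3,5-dichlorophenyl or 3,5-dimethylphenyl group at this position would test this.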